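The compounds below may be only part of what the source reports. "The series", "measured", "known", "first", "only" and "open" are said of these compounds alone.

In a functional assay on HO8910 cells (Homo sapiens) for inhibition, read by MTT assay, with a stated time of 24 h, tested at 1 ug/mL (a lower number here means less inhibition of growth, a higher number more inhibition of growth at the concentration tested), compound 1 `O=C(CCCCC1CCSS1)Nc1ccc(OC(F)(F)F)cc1` gives 10% of inhibition, compound 2 `O=C(CCCCC(S)CCS)Nc1ccc(Cl)cc1` gives 2.81% of inhibition and compound 3 `O=C(CCCCC(S)CCS)Nc1ccc(F)cc1` gives 12.2% of inhibition. Compound 3 lies within the scatter of both others, so these numbers set no firm order among them.

Compound 4 `O=C(CCCCC(S)CCS)Nc1ccc(OC(F)(F)F)cc1` differs from compound 3 in one place, on an aromatic carbon of a six-membered aromatic ring of carbon only. The change is trifluoromethoxy in place of fluoro on an aromatic carbon in all, with trifluoromethoxy in place of fluoro.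

For the measured compounds named here, the only measured step at this place is a number 9.4 percentage points higher from compound 2 to compound 3 (within the scatter) and it stays within the scatter. Compound 1 also carries trifluoromethoxy and shows 10% as its value, though the rest of its structure differs. This evidence is thin, but no step beyond the scatter is expected in this assay for this exchange. The estimated step is a number 2.2 percentage points lower from compound 3 to compound 4 (within the scatter) in size, with no clear direction. For compound 4 the estimated value is 10% with an expected range of 1% to 22% in repeated measurements.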

Compound 4, percent growth inhibition at one concentration: 0.56%
Beside the measured number, compound 4's estimate is 9.4 percentage points above it; measured number below the stated range.
By their numbers in this assay, from the lowest: compounds 4, 2, 1 and 3 (each within the scatter of the next, the first and the last beyond it).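

Trifluoromethoxy in place of fluoro, on an aromatic carbon para to a large group, gives the first step beyond the scatter in this assay: a number 11.6 percentage points lower from compound 3 to compound 4 (beyond the scatter). This position therefore responds to at least one exchange, yet the same group in place of chloro gives only a number 2.3 percentage points lower from compound 2 to compound 4 (within the scatter) and so separates compound 4 from only one of the two halogen compounds. Exchanging the five-membered non-aromatic ring for the open group with the same heavy atoms gives a number 9.4 percentage points lower from compound 1 to compound 4 (within the scatter), and nothing measured here explains any of these results.

On these data alone, it remains open how an amine or a nitrile would behave on this aromatic carbon. Also open, as far as these compounds go, is whether a longer chain in the shared core would shift these numbers.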